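The compounds below may be only part of what the source reports. "The series", "measured", "known", "first", "only" and "open" are said of these compounds alone.

Measured in a functional assay on SMMC-7721 cells (Homo sapiens) for antiproliferative activity, read by MTT assay, with a stated time of 72 h; on this read-out lower numbers stand for stronger inhibition and higher numbers for weaker inhibition:
- Compound 1 `CN(C(=O)c1ccc(Br)cc1)c1ccc2[nH]c(-c3n[nH]c4ccccc34)cc2n1`: 3460 nM
- Compound 2 `Cc1ccc(S(=O)(=O)N(C)c2ccc3[nH]c(-c4n[nH]c5ccccc45)cc3n2)cc1`: 16300 nM

Compound 2 has the higher of these two numbers, so it is the weaker inhibitor. Compound 3 `COc1ccc(OC)c(S(=O)(=O)N(C)c2ccc3[nH]c(-c4n[nH]c5ccccc45)cc3n2)c1` has not yet been measured. It differs from compound 2 in one place: 2,5-dimethoxyphenyl in place of 4-methylphenyl on a sulfonyl sulfur. Going by the values given here, the only measured step is a 4.7-fold higher number from compound 1 to compound 2 (0.67 log units; beyond the scatter). That modest step replaced the whole group on the nitrogen, so it shows nothing about changing the ring on a sulfonyl sulfur. No direction can be drawn from it, and no step beyond the scatter is expected in this assay. The expected step is a 1.5-fold lower number from compound 2 to compound 3 (0.17 log units; within the scatter). Compound 3 is estimated at 11000 nM, with an expected range of 3500 nM to 32000 nM.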

Compound 3, half-maximal inhibitory concentration: 4280 nM
Compound 3: the middle estimate sits 2.6-fold (0.41 log units) above what was measured; measured number inside the range.
By their numbers in this assay, from the lowest: compounds 1 and 3 (each within the scatter of the next); then compound 2.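

The ring on the sulfonyl sulfur is not a silent position in this assay: 2,5-dimethoxyphenyl in place of 4-methylphenyl gives a 3.8-fold lower number from compound 2 to compound 3 (0.58 log units; beyond the scatter) and so moves the number beyond the scatter. This single swap changes the ring's substituents as a whole, so it cannot show which part of the entering group matters. No measured evidence explains the change.

Still open, going by these compounds, is whether one methoxy group alone would give the same step. The compounds shown also leave open how an amine or a carboxylic acid on this ring would behave.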